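The source may hold more compounds than are shown below. What is called first, only, known or untested is meant among the compounds shown, and "the series" means these compounds.

Measured compounds:
compound 1 `COc1ccc(C(=O)/C=C/c2cc(OC)c(OC)c(OC)c2)c2c1C=CC(C)(C)O2`, > 10000 nM
compound 2 `COc1ccc(/C=C/C(=O)c2ccc(OC)c3c2OC(C)(C)C=C3)c(F)c1`, > 10000 nM
compound 3 `COc1ccc(C(=O)/C=C/c2ccc(OC)c(OC)c2OC)c2c1C=CC(C)(C)O2`, > 10000 nM

Compound 1 sits at a limit of a functional assay on HT-29 cells (Homo sapiens) for antiproliferative activity, read by MTT assay, with a stated time of 24 h (on this read-out higher numbers stand for weaker inhibition and lower numbers for stronger inhibition), not at a number. Compound 2 likewise gives only a limit in this assay. Compound 3 also reports a limit there. Every value of the series stands at the same limit, so compound 2 cannot be placed against the other two; all three show only that inhibition is weak (the limit of > 10000 nM in this assay, at which 3 of the 3 values shown sit).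

Compound 4 `COc1ccc(C(=O)/C=C/c2ccc(Cl)c(Cl)c2)c2c1C=CC(C)(C)O2` is not yet measured. It differs from compound 2 by 3,4-dichlorophenyl in place of 2-fluoro-4-methoxyphenyl on a double-bonded chain carbon bound to a double-bonded chain carbon. Within the data shown here, no measured step between compounds exists here. For this change a small step in this assay is expected, if any, with no clear direction and likely within the scatter. Compound 4 is therefore expected at about 15000 nM, between 3000 nM and 50000 nM, an expected step that the limit leaves unreadable from compound 2 to compound 4.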

Compound 4, half-maximal inhibitory concentration: 7580 nM
For compound 4 the middle estimate is 2.0-fold (0.30 log units) above the measured one; low and high end bracket the measured number.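

Among these compounds, with 3,4-dichlorophenyl on a double-bonded chain carbon bound to a double-bonded chain carbon, compound 4 gives the first number of the series rather than a limit, so this place can register a change in this assay and the series is not uniformly flat. Replacing 2-fluoro-4-methoxyphenyl reads as an at least 1.3-fold lower number from compound 2 to compound 4 (0.12 log units; that floor lies within the scatter) and only that floor is known. The full size of the step stays unreadable, and the series still rests mostly on one limit: the limit of > 10000 nM in this assay, at which 3 of the 4 values shown sit.

Which of the two chlorines matters stays open. So does whether an amine or a carboxylic acid on the phenyl ring at this place would move the number further.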